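The source may hold more compounds than are shown below. What is called first, only, known or untested is meant among the compounds shown, and "the series" means these compounds.

Working notes on the series. Among the measured compounds shown here, compound 1 `Cc1cc(O)nc(NC(=S)NC(=O)c2c(-c3ccc(Cl)cc3Cl)noc2C)n1` is the lower of the two numbers measured so far in a functional assay on the whole organism for inhibition, with Digitaria ciliaris as the target, with a stated time of 72 h, tested at 10 mg/L; a lower number here means less inhibition of growth, a higher number more inhibition of growth at the concentration tested: compound 1 gives -6.24% there. For the measured compounds named here, the other measured member, compound 2 `CSc1cc(C)nc2n/c(=N/C(=O)c3c(-c4ccc(Cl)cc4Cl)noc3C)sn12`, differs from compound 1 in more than one place, so no single step connects the two; in this assay compound 2 gives 26.8%, a number beyond the scatter above that of compound 1.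

The next compound, compound 3 `COc1cc(OC)nc(NC(=S)NC(=O)c2c(-c3ccc(Cl)cc3Cl)noc2C)n1`, changes compound 1 in a single place: 4,6-dimethoxypyrimidin-2-yl in place of 4-hydroxy-6-methylpyrimidin-2-yl on an amide-type nitrogen. Going by the values given here, no measured pair shows this exact change, so its effect is unknown from the series itself. The step from compound 1 to compound 3 is expected to be modest and upward, a number 21.2 percentage points higher from compound 1 to compound 3 (beyond the scatter), though a step within the scatter cannot be ruled out. On that basis, compound 3 is estimated to give 15% in this assay, with a range from -10% to 45%.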

Compound 3, percent growth inhibition at one concentration: 32%
Compound 3: the middle estimate sits 17 percentage points below what was measured; the range from low to high includes it.
By their numbers in this assay, from the lowest: compound 1; then compounds 2 and 3 (each within the scatter of the next).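

On the amide-type nitrogen whose other neighbour is the thiocarbonyl carbon, the group present clearly matters in this assay: 4,6-dimethoxypyrimidin-2-yl in place of 4-hydroxy-6-methylpyrimidin-2-yl gives a number 38.2 percentage points higher from compound 1 to compound 3 (beyond the scatter). Among the compounds shown here, this is the first single-place step, and the count of hydrogen-bond donors in the group goes from 1 to 0 while the ring itself stays the same. No measurement at hand accounts for the size of this step.

Hydroxy and methyl are both replaced in this one exchange, so the share of each remains open, and 4-methoxy-6-methylpyrimidin-2-yl would help to separate them. Also open, on these data alone, is how this assay responds to other groups here, such as 4,6-dimethylpyrimidin-2-yl or a pyrimidine bearing an amine.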